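Swapping the amine arm of a picomolar Bcl-2 binder

The source may hold more compounds than are shown below. What is called first, only, known or untested is meant among the compounds shown, and "the series" means these compounds.

Of the compounds shown here, three have been measured in an assay on isolated protein for displacement of a labelled ligand from Apoptosis regulator Bcl-2 (Homo sapiens), with a stated time of 15 min; a higher number here means a weaker inhibitor, a lower number a stronger inhibitor. Compound 1 `COc1ccc(C2=C(CN3CCN(c4ccc(C(=O)NS(=O)(=O)c5ccc(NCC6CCOCC6)c([N+](=O)[O-])c5)c(Oc5cnc6[nH]ccc6c5)c4)CC3)CCC(C)(C)C2)cc1` gives 3.8 nM. Among the compounds with values here, compound 2 `CC1(C)CCC(CN2CCN(c3ccc(C(=O)NS(=O)(=O)c4ccc(NCC5CCOCC5)c([N+](=O)[O-])c4)c(Oc4cnc5[nH]ccc5c4)c3)CC2)=C(c2ccccc2C(F)(F)F)C1` gives 1.7 nM; the single change between them, a 2-(trifluoromethyl)phenyl in place of 4-methoxyphenyl on a double-bonded ring carbon, yields a 2.2-fold lower number from compound 1 to compound 2 (0.35 log units; beyond the scatter). Compound 3 `CCN(CC)CCCNc1ccc(S(=O)(=O)NC(=O)c2ccc(N3CCN(CC4=C(c5ccc(C(F)(F)F)cc5)CC(C)(C)CC4)CC3)cc2Oc2cnc3[nH]ccc3c2)cc1[N+](=O)[O-]` gives 0.3 nM, the lowest number of the three and beyond the scatter from both others, so it is the strongest inhibitor of the set so far.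

Compound 4 `CC1(C)CCC(CN2CCN(c3ccc(C(=O)NS(=O)(=O)c4ccc(OCC5CCOCC5)c([N+](=O)[O-])c4)c(Oc4cnc5[nH]ccc5c4)c3)CC2)=C(c2ccc(C(F)(F)F)cc2)C1` differs from compound 3 in one place: (oxan-4-yl)methoxy in place of (3-(diethylamino)propyl)amino on an aromatic carbon. Within the data shown here, no measured pair in this set changes that position, so the one step that has been quantified, from compound 1 to compound 2, concerns a different part of the molecule and gives no direct guide. Compounds 1 and 2 do carry an (oxan-4-yl)methyl group on a nitrogen at the same aromatic carbon, and both show higher numbers than compound 3, though each also differs from compound 3 elsewhere, so the comparison is not clean.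

On that basis compound 4 is expected to remain a strong inhibitor, but with a somewhat higher number than compound 3, an estimated step of a 5.0-fold higher number from compound 3 to compound 4 (0.70 log units; beyond the scatter). The expected value for compound 4 in this assay is 1.5 nM, with a likely range from 0.4 nM to 6 nM.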

Compound 4, half-maximal inhibitory concentration: 1 nM
Beside the measured number, compound 4's estimate is 1.5-fold (0.18 log units) above it, and the stated range covers the measured number.
By their numbers in this assay, from the lowest: compound 3; then compounds 4 and 2 (each within the scatter of the next); then compound 1.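

Within the data shown here, this is the first direct reading of the group on the aromatic carbon ortho to the nitro group: (oxan-4-yl)methoxy in place of (3-(diethylamino)propyl)amino gives a 3.3-fold higher number from compound 3 to compound 4 (0.52 log units; beyond the scatter) in this assay. The step is modest but beyond the scatter, so this position does affect the read-out, yet it accepts a very different group, a ring-bearing ether arm with no hydrogen-bond donor, while compound 4 stays at 1 nM. The change replaces the linking nitrogen, the open chain and its diethylamino end all at once, and nothing measured here explains the shift.

The compounds shown cannot say which of those parts accounts for the step, and an (oxan-4-yl)methylamino arm on the exact skeleton of compound 4 would separate the linking atom from the rest of the arm. Also open, as far as these compounds go, is how this position would respond to a shorter amine arm such as (2-(dimethylamino)ethyl)amino, or to a longer chain ending in a carboxylic acid.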